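A few compounds are considered here, and "the series" means these few. Any claim that something is new, unique, unknown or untested is made for them only; others in the source may bear on it.

Compound 1 `Nc1nc(N2CCCC2)sc1C(=O)/C=C/c1ccccc1` and compound 2 `Nc1nc(N2CCCCC2)sc1C(=O)/C=C/c1ccccc1` share one core and differ only in the saturated ring attached to it. In a functional assay on SW480 cells (Homo sapiens) for antiproliferative activity, read by MTT assay, with a stated time of 48 h (a higher number here means a weaker inhibitor, a lower number a stronger inhibitor), compound 1 gives 31.7 ug/mL, and in this assay compound 2 gives 28.1 ug/mL; the step of a 1.1-fold lower number from compound 1 to compound 2 (0.05 log units; within the scatter) lies within the scatter, so these two values cannot be ordered. Among the measured compounds shown here, compound 2 carries the lowest number of the two so far, with compound 1 nearest to it and within the scatter.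

Compound 3 `Nc1nc(N2CCCCC2)sc1C(=O)/C=C/c1ccc([N+](=O)[O-])cc1` has not been measured in this assay. It differs from compound 2 by nitro in place of hydrogen on an aromatic carbon, on an aromatic carbon of a six-membered aromatic ring of carbon only, para to a large group. For the measured compounds named here, no measured step touches this ring: the single step measured, from compound 1 to compound 2, concerns a different part of the structure and lies within the scatter. The data therefore give no ground for a step in either direction, and for compound 3 no change beyond the scatter in this assay is expected. Compound 3 is estimated at 25 ug/mL, with a range from 8 ug/mL to 80 ug/mL. This estimate means an expected step of a 1.1-fold lower number from compound 2 to compound 3 (0.05 log units; within the scatter).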

Compound 3, half-maximal inhibitory concentration: 25.6 ug/mL
Compound 3: the middle estimate sits 1.0-fold (0.01 log units) below what was measured, and the stated range covers the measured number.
By their numbers in this assay, from the lowest: compounds 3, 2 and 1 (each within the scatter of the next).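

In this assay, among the compounds shown here, the nitro for hydrogen change gives the first measured step on the six-membered aromatic ring of carbon only, para to a large group: a 1.1-fold lower number from compound 2 to compound 3 (0.04 log units; within the scatter). For the compounds shown here, the earlier step concerned only the saturated ring, so this is the first reading on the aromatic ring, and replacing a hydrogen atom with a group of 3 heavy atoms at this position leaves the value within the scatter of compound 2. No measurement at hand bears on the reason for this result.

No step among the compounds shown lies beyond the scatter, so neither the saturated ring nor this aromatic position has yet been shown to move the value in this assay. Going by these compounds, it remains open whether an amine, a methoxy group or a carboxylic acid at this same position would give a step beyond the scatter, and whether nitro would read the same with pyrrolidin-1-yl in place of piperidin-1-yl.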